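This account rests on a few compounds, and the source may have more. Where it says the series, first, only, none or still open, it means among the compounds named here.

Measured so far in an ADME assay on MRC5 cells (Homo sapiens) for cytotoxicity, read by MTT assay, with a stated time of 72 h; a lower number here means a stronger inhibitor, a higher number a weaker inhibitor:
- compound 1 `O=C(COc1ccccc1)Nc1nnc(-c2cccc(O)c2O)s1`: 33900 nM
- compound 2 `O=C(Nc1nnc(-c2cccc(O)c2O)s1)c1ccccc1`: 23200 nM
- compound 3 `O=C(Nc1nnc(-c2ccc(O)c(O)c2)s1)C1CCCCC1`: 24000 nM

Compound 2 lies within the scatter of both other compounds, so the three cannot be ranked on these numbers. The next comparison is with compound 4 `Cc1ccc(C(=O)Nc2nnc(-c3cccc(O)c3O)s2)cc1`, which has methyl in place of hydrogen on an aromatic carbon, turning phenyl into 4-methylphenyl: methyl in place of hydrogen on an aromatic carbon.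

Going by the values given here, only one measured step bears on this change, and only indirectly. It is a 1.5-fold lower number from compound 1 to compound 2 (0.16 log units; within the scatter), where phenyl replaces phenoxymethyl on a carbonyl carbon, and it stays within the scatter. Among the compounds with values here, no measured step adds a methyl, so the size of this particular change is not known directly. Compound 3 differs from compound 2 in more than one place and gives no clean comparison, although compound 3 at 24000 nM also falls within the scatter of compound 2. A small change in this part of the structure is therefore not expected to move this assay beyond the scatter, in either direction. The expected step is a 1.0-fold lower number from compound 2 to compound 4 (0.00 log units; within the scatter).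

Compound 4 is expected at 23000 nM, with an estimated range of 12000 nM to 45000 nM.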

Compound 4, half-maximal inhibitory concentration: 33200 nM
Compound 4: the middle estimate sits 1.4-fold (0.16 log units) below what was measured; measured number inside the range.
By their numbers in this assay, from the lowest: compounds 2, 3, 4 and 1 (each within the scatter of the next).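

In this assay the direct reading of methyl in place of hydrogen, on an aromatic carbon of a six-membered aromatic ring of carbon only and para to a large group, is a 1.4-fold higher number from compound 2 to compound 4 (0.16 log units; within the scatter) and stays within the scatter, so this change does not separate the two compounds. The wider exchange of 4-methylphenyl in place of phenoxymethyl on a carbonyl carbon gives a 1.0-fold lower number from compound 1 to compound 4 (0.01 log units; within the scatter) and is also within the scatter, which means that phenoxymethyl, phenyl and 4-methylphenyl on this carbonyl carbon cannot be told apart in this assay on the values of compound 1, compound 2 and compound 4. No measured information bears on what lies behind these small steps.

Going by these compounds, every step read so far in this part of the series lies within the scatter, so it remains open whether any group at this position can move the number beyond it. An amine, a carboxylic acid or a longer chain in place of the methyl of compound 4 would test this, as would a carboxylic acid in place of the whole 4-methylphenyl group on the carbonyl carbon.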